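Swapping the Ring on the Piperazine Nitrogen

The compounds below may be only part of what the source reports. "The series", "measured", "known", "first", "only" and "open" are said of these compounds alone.

In an assay on brain for binding affinity to Adrenergic receptor alpha-1 (Rattus norvegicus) (on this read-out higher numbers stand for weaker inhibition and lower numbers for stronger inhibition), compound 3 `COc1cc2nc(N3CCN(c4ccc(OC(C)C)nn4)CC3)nc(N)c2cc1OC` gives 0.29 nM. Compound 1 `COc1cc2nc(N3CCN(c4ncccn4)CC3)nc(N)c2cc1OC` gives 0.26 nM and compound 2 `COc1cc2nc(N3CCN(c4nccc(N(C)C)n4)CC3)nc(N)c2cc1OC` gives 0.27 nM; the steps of a 1.1-fold higher number from compound 1 to compound 3 (0.05 log units; within the scatter) and a 1.1-fold higher number from compound 2 to compound 3 (0.03 log units; within the scatter) both stay within the scatter, as does a 1.0-fold higher number from compound 1 to compound 2 (0.02 log units; within the scatter), so all three numbers sit together. Compound 4 `COc1nc(OC)nc(N2CCN(c3nc(N)c4cc(OC)c(OC)cc4n3)CC2)n1` differs from compound 3 by 4,6-dimethoxy-1,3,5-triazin-2-yl in place of 6-isopropoxypyridazin-3-yl on an amine nitrogen in a ring. The two measured steps that exchange the ring on that piperazine nitrogen bear on this change, and neither moved this assay. Because the steps of a 1.1-fold higher number from compound 1 to compound 3 (0.05 log units; within the scatter) and a 1.1-fold higher number from compound 2 to compound 3 (0.03 log units; within the scatter) stayed within the scatter, compound 4 is expected to show a 1.0-fold higher number from compound 3 to compound 4 (0.01 log units; within the scatter). Compound 4 is therefore estimated at 0.3 nM, with a range from 0.1 nM to 1 nM.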

Compound 4, inhibition constant: 0.08 nM
For compound 4 the middle estimate is 3.8-fold (0.57 log units) above the measured one, and the stated range ends above it.
By their numbers in this assay, from the lowest: compound 4; then compounds 1, 2 and 3 (each within the scatter of the next).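

The ring on this piperazine nitrogen can matter in this assay after all: with 4,6-dimethoxy-1,3,5-triazin-2-yl in place, the read-out shows a 3.6-fold lower number from compound 3 to compound 4 (0.56 log units; beyond the scatter), along with a 3.4-fold lower number from compound 2 to compound 4 (0.53 log units; beyond the scatter) and a 3.3-fold lower number from compound 1 to compound 4 (0.51 log units; beyond the scatter). Compound 4 therefore stands apart from the other three compounds, whose numbers sit within the scatter of one another. No measurement at hand explains this difference.

The compounds shown do not separate the contribution of the two methoxy groups from that of the triazine ring itself. From the compounds shown here alone, it also remains open whether a triazine carrying an amine or a longer ether chain in place of methoxy would keep the lower number.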